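This account rests on a few compounds, and the source may have more. Where it says the series, first, only, none or still open, it means among the compounds named here.

Among the measured compounds shown here, compound 2 `CC(C)(C)c1cc(NC(=O)[C@@H]2CCCCN2C2CCOCC2)no1` gives 74 ug/mL in a physicochemical assay for solubility, read by HPLC, at pH 6.8 (a lower number here means a less soluble compound, a higher number a more soluble compound), the only number among the values shown. Compound 1 `CC(C)(C)c1cc(NC(=O)[C@@H]2CCCCN2Cc2ccc(Cl)cc2)no1` is known in this assay only by a limit, < 0.1 ug/mL. The step of an at least 740-fold higher number from compound 1 to compound 2 (2.86 log units; beyond the scatter) is large, though its start is set by the limit of < 0.1 ug/mL in this assay, at which 1 of the 2 values shown sits. Compound 3 `CC(C)(C)c1cc(NC(=O)[C@@H]2CCCCN2CC2CCOCC2)no1` differs from compound 2 by (oxan-4-yl)methyl in place of oxan-4-yl on an amine nitrogen in a ring. This change is far smaller in kind than the measured one, so compound 3 is expected to shift by a 1.9-fold lower number from compound 2 to compound 3 (0.27 log units; within the scatter), a lowering that may stay within the scatter. Compound 3 is therefore estimated at 40 ug/mL, between 15 ug/mL and 100 ug/mL.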

Compound 3, solubility: 72 ug/mL
Compound 3: the middle estimate sits 1.8-fold (0.26 log units) below what was measured; the measured number falls inside the stated range.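

Putting (oxan-4-yl)methyl in place of oxan-4-yl on this amine nitrogen gives a 1.0-fold lower number from compound 2 to compound 3 (0.01 log units; within the scatter), so this assay does not tell these two groups apart. Compound 1 and compound 3 both keep a saturated chain carbon on that nitrogen, and oxan-4-yl in place of 4-chlorophenyl on that carbon gives an at least 720-fold higher number from compound 1 to compound 3 (2.85 log units; beyond the scatter), so the large step also appears with this carbon retained. The start of that step, compound 1, is a limit: the limit of < 0.1 ug/mL in this assay, at which 1 of the 3 values shown sits.

The compounds shown leave open whether a longer chain carrying the oxan-4-yl ring would keep this reading. They also leave open how cyclohexyl, with carbon in place of the ring oxygen, or a piperidine ring would read.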